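This account rests on a few compounds, and the source may have more. Where it says the series, first, only, none or still open, it means among the compounds named here.

Among the measured compounds shown here, in a functional assay on HeLa cells (Homo sapiens) for inhibition, read by MTT assay, with a stated time of 48 h (a higher number here means a weaker inhibitor, a lower number a stronger inhibitor), compound 2 `CCOC(=O)C1=C(N/C=N/c2nnc(S(N)(=O)=O)s2)Nc2[nH]nc(C)c2C1c1ccc(N(C)C)cc1` gives 26300 nM, the higher of the two numbers measured so far, while compound 1 `CCOC(=O)C1=C(N/C=N/c2cccnc2Cl)Nc2[nH]nc(C)c2C1c1ccc(N(C)C)cc1` gives 4630 nM. Compound 3 `CCOC(=O)C1=C(N/C=N/c2ncc(-c3ccccc3)s2)Nc2[nH]nc(C)c2C1c1ccc(N(C)C)cc1` keeps the shared core and changes one group: 5-phenyl-1,3-thiazol-2-yl in place of 5-sulfamoyl-1,3,4-thiadiazol-2-yl on a double-bonded nitrogen. For the measured compounds named here, the only measured step at this place is a 5.7-fold higher number from compound 1 to compound 2 (0.75 log units; beyond the scatter), modest and beyond the scatter. Going by the values given here, compound 3 gives up the group that went with the higher number in that step, but no measured compound carries the entering group. The expected step is therefore modest: a 2.9-fold lower number from compound 2 to compound 3 (0.47 log units; beyond the scatter). For compound 3 the estimated value is 9000 nM, with an expected range from 2500 nM to 30000 nM.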

Compound 3, half-maximal inhibitory concentration: 15400 nM
For compound 3 the middle estimate is 1.7-fold (0.23 log units) below the measured one; the measured number falls inside the stated range.
By their numbers in this assay, from the lowest: compound 1; then compounds 3 and 2 (each within the scatter of the next).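

At this place, on a double-bonded nitrogen, 5-phenyl-1,3-thiazol-2-yl and 5-sulfamoyl-1,3,4-thiadiazol-2-yl cannot be told apart in this assay (a 1.7-fold lower number from compound 2 to compound 3 (0.23 log units; within the scatter)), although they share little beyond a five-membered aromatic ring. The 2-chloropyridin-3-yl group now stands apart from two different groups rather than one (a 3.3-fold higher number from compound 1 to compound 3 (0.52 log units; beyond the scatter)). Nothing available explains this difference. The compounds shown leave open how a pyridin-3-yl without the chlorine would read at this place. As far as these compounds go, how a phenyl ring carrying an amine would read also remains open.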